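The source may report more compounds than this note shows. Statements on the series, on what has been measured and on what is new or still open speak of the compounds shown alone.

Compound 1 `CC(=O)N1CCN(c2ccc(Nc3nccc(-c4cn(C)c5ccccc45)n3)cc2)CC1` sits in a small set of three built on a shared core. In a functional assay on MV4-11 cells (Homo sapiens) for antiproliferative activity, read by resazurin assay, with a stated time of 72 h (a higher number here means a weaker inhibitor of growth, a lower number a stronger inhibitor of growth), compound 1 gives 252 nM, the second highest of the three numbers: compound 3 `CC(=O)N1CCN(c2ccc(Nc3nccc(-c4cn(S(=O)(=O)c5ccc(C)cc5)c5ccccc45)n3)cc2)CC1` gives 1560 nM, and the step of a 6.2-fold higher number from compound 1 to compound 3 (0.79 log units; beyond the scatter) goes with (4-methylphenyl)sulfonyl in place of methyl on an aromatic nitrogen, while compound 2 `CC(=O)N1CCCN(c2cccc(Nc3nccc(-c4cnc5n(C)cccc4-5)n3)c2)CC1` gives 24 nM but differs from compound 1 in several places at once. Compound 4 `CC(=O)N1CCN(c2ccc(Nc3nccc(-c4cn(C)c5ncccc45)n3)cc2)CC1` differs from compound 1 in one place: a group of 10 heavy atoms (8 carbon, 2 nitrogen; one five-membered aromatic ring with 1 hetero atom, one six-membered aromatic ring with 1 hetero atom) in place of a group of 10 heavy atoms (9 carbon, 1 nitrogen; one five-membered aromatic ring with 1 hetero atom, one six-membered aromatic ring of carbon only), on an aromatic carbon. Within the data shown here, no measured step shares this change, since the only measured step concerns the group on the aromatic nitrogen. One group of 10 heavy atoms replaces another of 10 heavy atoms, so a step within the scatter is expected, a 1.1-fold lower number from compound 1 to compound 4 (0.06 log units; within the scatter). Compound 4 is therefore estimated at 220 nM, with a range from 80 nM to 600 nM.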

Compound 4, concentration for 50% growth inhibition: 74 nM
Beside the measured number, compound 4's estimate is 3.0-fold (0.47 log units) above it, and the stated range ends above it.
By their numbers in this assay, from the lowest: compound 2; then compound 4; then compound 1; then compound 3.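

In this assay, the group on the aromatic carbon also matters, not only the group on the aromatic nitrogen: a nitrogen in the six-membered ring in place of carbon goes with a 3.4-fold lower number from compound 1 to compound 4 (0.53 log units; beyond the scatter), a shift towards stronger inhibition of growth. The heavy-atom count stays the same, so size alone does not set the number at this position. Nothing measured here accounts for this step.

On these data alone, whether the shift depends on where that ring nitrogen sits remains open. So does whether a methoxy group or an amine on the same six-membered ring would shift the number the same way.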